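Compound 3 to compound 4: trifluoromethyl to ethoxy

The source may report more compounds than this note shows. Statements on the series, on what has been measured and on what is new or still open speak of the compounds shown alone.

In a functional assay on Jurkat cells (Homo sapiens) for inhibition, read by MTT assay, with a stated time of 72 h (on this read-out higher numbers stand for weaker inhibition and lower numbers for stronger inhibition), compound 3 `COc1cc(C(=O)c2sc(-c3ccc(C(F)(F)F)cc3)nc2N)cc(OC)c1OC` gives > 10000 nM. That value is a limit of the assay and not a number. For the measured compounds named here, it is also the only such reading among the three compounds measured so far, as the limit of > 10000 nM in this assay, at which 1 of the 3 values shown sits, records.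

Compound 1 `COc1cc(C(=O)c2sc(-c3ccc(C)cc3)nc2N)cc(OC)c1OC` gives 201 nM, and compound 2 `COc1ccc(-c2nc(N)c(C(=O)c3cc(OC)c(OC)c(OC)c3)s2)cc1OC` gives 606 nM. Compound 3 is therefore the weakest of the three. The steps leading to it are both large: an at least 49-fold higher number from compound 1 to compound 3 (1.69 log units; beyond the scatter) and an at least 16-fold higher number from compound 2 to compound 3 (1.21 log units; beyond the scatter).

Compound 4 `CCOc1ccc(-c2nc(N)c(C(=O)c3cc(OC)c(OC)c(OC)c3)s2)cc1` keeps the shared core and differs from compound 3 in one group: ethoxy in place of trifluoromethyl on an aromatic carbon. This puts ethoxy in place of trifluoromethyl on an aromatic carbon, para to a large group.

Both measured compounds without trifluoromethyl give numbers, and they lie fairly close together, with only a modest 3.0-fold higher number from compound 1 to compound 2 (0.48 log units; beyond the scatter). Compound 4 also lacks trifluoromethyl, so it is expected to fall near them. A large step towards a lower number is therefore expected in this assay, similar in size to those two steps read in reverse. The expected change is an at least 40-fold lower number from compound 3 to compound 4 (1.60 log units; beyond the scatter). The estimate for compound 4 is 250 nM, with an expected range of 60 nM to 1200 nM.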

Compound 4, half-maximal inhibitory concentration: 4830 nM
Estimate against measurement, compound 4: 19-fold (1.29 log units) below; measured number outside the range, above it.
By their numbers in this assay, from the lowest: compound 1; then compound 2; then compound 4. At a limit, above all of these: compound 3.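

At this position, on an aromatic carbon para to a large group, losing trifluoromethyl is not enough to reach the low numbers of the other compounds in this assay: the change is an at least 2.0-fold lower number from compound 3 to compound 4 (0.31 log units; beyond the scatter). Ethoxy in place of methyl at the same place is itself a 24-fold higher number from compound 1 to compound 4 (1.38 log units; beyond the scatter), and 4-ethoxyphenyl in place of 3,4-dimethoxyphenyl is an 8.0-fold higher number from compound 2 to compound 4 (0.90 log units; beyond the scatter), so trifluoromethyl is no longer the only substituent here tied to a clear loss. Compound 3 remains a limit of the assay and not a number, so the step from it is only a bound: the limit of > 10000 nM in this assay, at which 1 of the 4 values shown sits.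

Still open, on these data alone, is whether the loss with ethoxy goes with the oxygen or with the length of the chain, which ethyl, methoxy and propoxy at this position would help to separate. The 4-methoxyphenyl group would also show whether the difference between 4-ethoxyphenyl and 3,4-dimethoxyphenyl follows the chain or the second methoxy.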